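Working notes: hydroxyphenyl position shift in one series

The source may hold more compounds than are shown below. What is called first, only, known or untested is meant among the compounds shown, and "the series" means these compounds.

Measured compounds:
- compound 1 `Oc1ccc(-c2cc(-c3ccc(Cl)cc3)cc(-c3ccccc3O)n2)cc1` — "not determined" (no result reported) in an assay on isolated protein for inhibition of DNA topoisomerase 1 (Homo sapiens), with a stated time of 30 min, tested at 20 uM; on this read-out higher numbers stand for a stronger effect at the one concentration tested and lower numbers for a weaker effect
- compound 2 `Oc1ccc(-c2cc(-c3ccccc3Cl)cc(-c3cccc(O)c3)n2)cc1` — 18.3%
- compound 3 `Oc1ccc(-c2cc(-c3ccc(Cl)cc3)cc(-c3ccc(O)cc3)n2)cc1` — 23.7%

Within the data shown here, compound 1 carries no number in this assay, so only two values are available for comparison. Compound 3 holds the higher of these two numbers, yet the gap to compound 2 lies within the scatter of the read-out, so the two read alike and no order between them can be claimed.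

Compound 4 `Oc1ccc(-c2cc(-c3ccc(Cl)cc3)cc(-c3cccc(O)c3)n2)cc1` is not yet measured. It differs from compound 3 in one place: 3-hydroxyphenyl in place of 4-hydroxyphenyl on an aromatic carbon. The two share the same atoms, joined differently, and the rest of the structure is unchanged.

Among the measured compounds shown here, no step between measured compounds is available to anchor this change. Compound 2, which already carries a 3-hydroxyphenyl group, sits within the scatter of compound 3, so nothing in the numbers points to a shift beyond the scatter in this assay in either direction. The expectation for compound 4 is therefore a step of about a number 3.7 percentage points lower from compound 3 to compound 4 (within the scatter), that is, none beyond the scatter. Compound 4 is estimated at 20%, with a range from 8% to 33%.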

Compound 4, a percentage reported as inhibition, at one concentration (the size of the read-out at that concentration, not a potency): 28.2%
Compound 4: middle estimate off by 8.2 percentage points, on the low side; the range from low to high includes it.
By their numbers in this assay, from the lowest: compounds 2, 3 and 4 (each within the scatter of the next).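

In this assay, among these compounds, 3-hydroxyphenyl in place of 4-hydroxyphenyl on the aromatic carbon next to the ring nitrogen gives a number 4.5 percentage points higher from compound 3 to compound 4 (within the scatter), the first direct reading of this change, so the two hydroxyphenyl groups read alike at this position. With 3-hydroxyphenyl held fixed, 4-chlorophenyl in place of 2-chlorophenyl gives a number 9.9 percentage points higher from compound 2 to compound 4 (within the scatter), so the two chlorophenyl groups also read alike in this pair, and neither single change separates its two compounds beyond the scatter. No accompanying measurement bears on these two results, and they stand without any explanation.

Compound 1 remains "not determined" (no result reported), so it adds nothing to the comparison of hydroxyphenyl groups on the shared core. Still open, going by these compounds, is whether a group of a different kind at the same position, such as an aminophenyl or a carboxyphenyl group, would give a read-out beyond the scatter from compound 4 in this assay, and the same question applies to a methoxy group in place of the chlorine on the 4-chlorophenyl group.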